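Dimethylamino swap in a series held at the limit

This account rests on a few compounds, and the source may have more. Where it says the series, first, only, none or still open, it means among the compounds named here.

The series keeps one shared core and varies the amine on a saturated chain carbon bound to an aromatic carbon. In a functional assay on HeLa cells (Homo sapiens) for antiproliferative activity, read by MTT assay, with a stated time of 48 h (on this read-out lower numbers stand for stronger inhibition and higher numbers for weaker inhibition), compound 1 (`O=C(NO)c1cn(C2CC2)c2cc(-n3cc(CN4CCCCC4)nn3)c(F)cc2c1=O`) gives > 10000 nM as a limit of the assay. In this assay compound 2 (`CC(C)NCc1cn(-c2cc3c(cc2F)c(=O)c(C(=O)NO)cn3C2CC2)nn1`) gives > 10000 nM as a limit too. In this assay compound 3 (`CCCN(CCC)Cc1cn(-c2cc3c(cc2F)c(=O)c(C(=O)NO)cn3C2CC2)nn1`) gives > 10000 nM as a limit as well, so it has no number of its own. Among the compounds with values here, the whole series so far shows the limit of > 10000 nM in this assay, at which 3 of the 3 values shown sit, and nothing else.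

The next change leads to compound 4 (`CN(C)Cc1cn(-c2cc3c(cc2F)c(=O)c(C(=O)NO)cn3C2CC2)nn1`), with dimethylamino in place of dipropylamino on a saturated chain carbon bound to an aromatic carbon at the same place.

The steps bearing on it are a step that the two limits leave unreadable from compound 1 to compound 3 and a step that the two limits leave unreadable from compound 2 to compound 3 and neither has a readable size. Since compound 3 sits at > 10000 nM as a limit, no step beyond the scatter is expected in this assay for this change. The estimated step is a step that the limit leaves unreadable from compound 3 to compound 4 and carries little weight. Compound 4 is expected at 15000 nM within an estimated range of 6000 nM to 40000 nM and most likely as a limit again.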

Compound 4, half-maximal inhibitory concentration: > 10000 nM
Compound 4: only a limit was reported (the forecaster's own chance of this, stated with the estimate: 85%); the middle value lies beyond the limit too.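

In this assay compound 4 gives > 10000 nM, again a limit of the assay, so its steps from compound 1, compound 2 and compound 3 cannot be read. The compounds shown leave open how these amines rank on the shared core, because none has a number of its own: the limit of > 10000 nM in this assay, at which 4 of the 4 values shown sit.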